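Pyridylmethylamine isomers on the shared core: compound 3 expected

This account rests on a few compounds, and the source may have more. Where it says the series, first, only, none or still open, it means among the compounds named here.

Measured so far:
- compound 1, `COc1cc(C(=O)O)ccc1NC(=O)[C@@H]1N[C@@H](CC(C)(C)C)[C@](CNCc2cccnc2)(c2ccc(Cl)cc2F)[C@H]1c1cccc(Cl)c1F`: 1140 nM
- compound 2, `COc1cc(C(=O)O)ccc1NC(=O)[C@@H]1N[C@@H](CC(C)(C)C)[C@](CNCc2ccncc2)(c2ccc(Cl)cc2F)[C@H]1c1cccc(Cl)c1F`: 520 nM

Compound 2 gives 520 nM in a functional assay on MCF7 cells (Homo sapiens) for inhibition, read by CCK-8 assay, with a stated time of 4 days (a lower number here means a stronger inhibitor, a higher number a weaker inhibitor), the lower of the two numbers in hand. For the measured compounds named here, its only neighbour is compound 1, and the step of a 2.2-fold lower number from compound 1 to compound 2 (0.34 log units; beyond the scatter) separates them, so compound 2 stands beyond the scatter from compound 1.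

Compound 3, `COc1cc(C(=O)O)ccc1NC(=O)[C@@H]1N[C@@H](CC(C)(C)C)[C@](CNCc2ccccn2)(c2ccc(Cl)cc2F)[C@H]1c1cccc(Cl)c1F`, is the remaining isomer of the pair. It differs from compound 2 only by pyridin-2-yl in place of pyridin-4-yl on a saturated chain carbon bound to an amine nitrogen.

Going by the values given here, the single step that bears on this change is a 2.2-fold lower number from compound 1 to compound 2 (0.34 log units; beyond the scatter), a modest move that came from shifting the ring nitrogen within the same six-membered aromatic ring. Compound 3 shifts that nitrogen once more. Among the compounds with values here, with only one isomer step known and no case of pyridin-2-yl, the direction cannot be read from the data; a step of similar size in either direction, or none beyond the scatter, is plausible.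

Compound 3 is therefore expected to give about 700 nM in this assay, within 250 nM to 2000 nM, which corresponds to an expected step of a 1.3-fold higher number from compound 2 to compound 3 (0.13 log units; within the scatter).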

Compound 3, half-maximal inhibitory concentration: 720 nM
Estimate against measurement, compound 3: 1.0-fold (0.01 log units) below; the range from low to high includes it.
By their numbers in this assay, from the lowest: compounds 2, 3 and 1 (each within the scatter of the next, the first and the last beyond it).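

In this assay, pyridin-2-yl in place of pyridin-4-yl gives a 1.4-fold higher number from compound 2 to compound 3 (0.14 log units; within the scatter), and pyridin-2-yl in place of pyridin-3-yl gives a 1.6-fold lower number from compound 1 to compound 3 (0.20 log units; within the scatter), so compound 3 cannot be separated from either isomer. For the compounds shown here, the one step beyond the scatter remains a 2.2-fold lower number from compound 1 to compound 2 (0.34 log units; beyond the scatter), and it is a modest one; across the three pyridine isomers on a saturated chain carbon bound to an amine nitrogen, moving the ring nitrogen therefore gives a narrow spread of values, with no clear rank for pyridin-2-yl. No measurement is available to explain these small differences.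

The compounds shown leave open whether the ring nitrogen is needed at all, which a phenyl ring in place of the pyridine would test, and whether a pyrimidinyl ring, with a second ring nitrogen, would move the value beyond this narrow spread. They also leave open whether a longer chain in place of the methyl link to the pyridine ring would preserve the small size of these isomer steps, or whether the same steps would hold with the carboxylic acid of the shared core replaced by a primary amide.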